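Chain extension from compound 2 to compound 3

A few compounds are considered here, and "the series" means these few. Any claim that something is new, unique, unknown or untested is made for them only; others in the source may bear on it.

Compound 1 `CCn1c(C(=O)NC2(CO)CC2)ccc1C(CC)(CC)c1ccc(OCS(=O)(=O)c2ccccc2)c(C)c1` reads 28800 nM in a functional assay on MCF7 cells (Homo sapiens) for antiproliferative activity, read by MTT assay, with a stated time of 24 h; on this read-out higher numbers stand for weaker inhibition and lower numbers for stronger inhibition
Compound 2 `CCn1c(C(=O)N[C@@H](CC(=O)O)C(=O)O)ccc1C(CC)(CC)c1ccc(OCS(=O)(=O)c2ccccc2)c(C)c1` reads > 50000 nM as a limit in this assay

Compound 2 therefore stands at a limit and offers no number to step from. Compound 3 `CCn1c(C(=O)N[C@@H](CCC(=O)O)C(=O)O)ccc1C(CC)(CC)c1ccc(OCS(=O)(=O)c2ccccc2)c(C)c1` has carboxymethyl in place of carboxy on a saturated chain carbon, two bonds along the chain from an amide-type nitrogen and a carbonyl carbon and so carries 1,3-dicarboxypropyl where compound 2 has 1,2-dicarboxyethyl. For the measured compounds named here, the one measured step that bears on this, 1,2-dicarboxyethyl in place of 1-(hydroxymethyl)cyclopropyl, is an at least 1.7-fold higher number from compound 1 to compound 2 (0.23 log units; that floor lies within the scatter) and gives only a floor. Going by the values given here, no measured step covers this chain change, so no step beyond the scatter is expected in this assay and another limit is likely. The expected step is a number no higher from compound 2 to compound 3 (the limit leaves the size open) and no more. For compound 3 the estimate is 50000 nM with an expected range of 25000 nM to 100000 nM overall.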

Compound 3, half-maximal inhibitory concentration: > 50000 nM
Compound 3: only a limit was reported; the forecaster's own chance of this, stated with the estimate: 60%; the middle value sits exactly at the limit.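

Carboxymethyl in place of carboxy, on a saturated chain carbon, two bonds along the chain from an amide-type nitrogen and a carbonyl carbon, gives no readable change in this assay, and the step between the two limits cannot be read. 1,3-Dicarboxypropyl in place of 1-(hydroxymethyl)cyclopropyl gives an at least 1.7-fold higher number from compound 1 to compound 3 (0.23 log units; that floor lies within the scatter), again only a floor. The longer of the two dicarboxy chains thus brings no number back into range, and both chains end at the same reported limit: the limit of > 50000 nM in this assay, at which 2 of the 3 values shown sit.

As far as these compounds go, how far compound 2 and compound 3 lie past that limit stays open, and with it whether this chain change has any effect at all. Also open, from the compounds shown here alone, is whether an amine in place of a carboxylic acid, or a longer chain, would give a readable number.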